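The source may report more compounds than this note shows. Statements on the series, on what has been measured and on what is new or still open speak of the compounds shown alone.

Of the compounds shown here, three have been measured in a functional assay on HepG2 cells (Homo sapiens) for cytotoxicity, read by MTT assay, with a stated time of 72 h; on this read-out higher numbers stand for weaker inhibition and lower numbers for stronger inhibition. Compound 1 `O=C(Nc1ccc(Oc2ccnc3[nH]ccc23)cc1)c1nn(-c2ccc(Cl)cc2)ccc1=O` gives 19500 nM in this assay. Compound 2 `COc1ccc(-n2ccc(=O)c(C(=O)Nc3ccc(Oc4ccnc5[nH]ccc45)cc3)n2)cc1` carries one change relative to compound 1, namely (methoxy in place of chloro on an aromatic carbon), and in this assay compound 2 gives 50800 nM. That single change made the step of a 2.6-fold higher number from compound 1 to compound 2 (0.42 log units; beyond the scatter). Compound 3 `Cn1ccc2c(Oc3ccc(NC(=O)c4nn(-c5ccc(Cl)cc5)ccc4=O)cc3F)ccnc21` reaches only a limit of this assay, > 60000 nM, and not a number. How the core of compound 3 differs from the core of compound 1 is not broken down here. Compound 4 `COc1ccc(-n2ccc(=O)c(C(=O)Nc3ccc(Oc4ccnc5c4ccn5C)c(F)c3)n2)cc1` has not yet been measured; it differs from compound 3 by methoxy in place of chloro on an aromatic carbon, which is the same change as that made between compound 1 and compound 2. The step from compound 3 to compound 4 is expected to be a step that the limit leaves unreadable from compound 3 to compound 4, an expectation that rests on the step of a 2.6-fold higher number from compound 1 to compound 2 (0.42 log units; beyond the scatter), which went toward weaker inhibition, and on (the limit of > 60000 nM in this assay, at which 1 of the 3 values shown sits). Compound 4 is therefore estimated at 120000 nM, between 60000 nM and 300000 nM, and is expected most likely to be reported only as a limit.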

Compound 4, half-maximal inhibitory concentration: > 60000 nM
Compound 4 gave a limit, no number; the forecaster's own chance of this, stated with the estimate: 90%; the middle value does not contradict the limit.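

Compound 3 and compound 4 both reach a limit of this assay rather than a number, so no step can be read between them: the limit of > 60000 nM in this assay, at which 2 of the 4 values shown sit.

The compounds shown leave open whether methoxy in place of chloro weakens inhibition on the core of compound 3, as it does on the core of compound 1.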